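A few compounds are considered here, and "the series" means these few. Any claim that something is new, unique, unknown or untested is made for them only; others in the source may bear on it.

Measured compounds in a physicochemical assay for metabolic stability, read by LC-MS, in phosphate buffer, with a stated time of 3 h, at pH 7.4, tested at 50 uM; a higher number here means that more of the compound is left, a lower number that less of the compound is left:
Compound 1 `C[C@@H](O)[C@H]1C(=O)N2C(C(=O)OCOC(=O)C(C)(C)C)=C(S[C@@H]3CN[C@H](C(=O)Nc4cccc(C(=O)O)c4)C3)[C@H](C)[C@H]12` gives > 95%, which is a limit of the assay and not a number.
Compound 2 `CCC(CC)C(=O)OCOC(=O)C1=C(S[C@@H]2CN[C@H](C(=O)Nc3cccc(C(=O)O)c3)C2)[C@H](C)[C@@H]2[C@@H]([C@@H](C)O)C(=O)N12` gives > 95%, which is likewise a limit of the assay.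

Going by the values given here, compound 2 therefore stands at the upper edge of what this assay reports, and the only other measured compound stands at the same edge, as the limit of > 95% in this assay, at which 2 of the 2 values shown sit, shows. Among the compounds with values here, the single measured step, a step that the two limits leave unreadable from compound 1 to compound 2, runs between two limits, so its size cannot be read. Compound 3 `C[C@@H](O)[C@H]1C(=O)N2C(C(=O)OCOC(=O)OC3CCCCC3)=C(S[C@@H]3CN[C@H](C(=O)Nc4cccc(C(=O)O)c4)C3)[C@H](C)[C@H]12` differs from compound 2 by cyclohexyloxy in place of pentan-3-yl on a carbonyl carbon. The measured step concerns the same place in the molecule, but it offers no readable size that could be carried over. Both measured compounds sit at the limit because the limit of > 95% in this assay, at which 2 of the 2 values shown sit, holds for every value shown, and on that basis the change is expected to produce no step beyond the scatter. Compound 3 is thus expected to give 95% in this assay, with a range from 87% to 98%. The expected step is a number no higher from compound 2 to compound 3 (the limit leaves the size open), most likely reported again only as a limit.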

Compound 3, percent of the compound remaining: > 95%
Compound 3: no number, only a limit (the forecaster's own chance of this, stated with the estimate: 75%); the middle value sits exactly at the limit.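

In this assay the steps linking compound 3 to compound 1 and compound 2 cannot be read, as all three compounds give a limit and not a number: the limit of > 95% in this assay, at which 3 of the 3 values shown sit.

The compounds shown leave open how far apart these three really lie, and whether any change at this place on the carbonyl carbon would leave less compound remaining.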